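The source may hold more compounds than are shown below. What is called first, only, known or untested is meant among the compounds shown, and "the series" means these compounds.

In a functional assay (blood) for inhibition, with Homo sapiens as the target (on this read-out higher numbers stand for weaker inhibition and lower numbers for stronger inhibition), compound 1 `CCCC(Oc1ccc2c(c1)c(SC(C)(C)C)c(CC(C)(C)C(=O)O)n2Cc1ccc(Cl)cc1)c1ccc2ccccc2n1` gives > 3000 nM which is a limit of the assay and not a number. Compound 2 `CC(C)(C)Sc1c(CC(C)(C)C(=O)O)n(Cc2ccc(Cl)cc2)c2ccc(CCc3ccc4ccccc4n3)cc12` gives > 3000 nM which is likewise a limit. Among the compounds with values here, compound 3 `CC(C)(C)Sc1c(CC(C)(C)C(=O)O)n(Cc2ccc(Cl)cc2)c2ccc(OCc3ccc4cc(F)ccc4n3)cc12` gives 880 nM and so holds the only actual number of the three. Compound 4 `CC(C)(C)Sc1c(CC(C)(C)C(=O)O)n(Cc2ccc(Cl)cc2)c2ccc(OCc3ccc4cc(F)c(F)cc4n3)cc12` is compound 3 changed in one place: fluoro in place of hydrogen on an aromatic carbon with fluoro in place of hydrogen on an aromatic carbon, ortho to a fluoro group. No measured step among these compounds speaks to this change, so in this assay no shift beyond the scatter is expected in either direction. The expected step of a 1.1-fold lower number from compound 3 to compound 4 (0.04 log units; within the scatter) is estimated to stay small. Compound 4 is estimated at 800 nM with an expected range from 300 nM to 2500 nM in this read-out.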

Compound 4, half-maximal inhibitory concentration: > 3000 nM
Compound 4 was reported as a limit; the forecaster's own chance of this, stated with the estimate: 12%; middle value at least 3.7-fold (0.57 log units) from the limit.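

In this assay, within the data shown here, adding fluoro on this aromatic carbon, ortho to a fluoro group, gives an at least 3.4-fold higher number from compound 3 to compound 4 (0.53 log units; beyond the scatter), the first measured step at this position and one beyond the scatter. Compound 4 gives > 3000 nM, which is a limit and not a number. The full size of the step therefore cannot be read: the limit of > 3000 nM in this assay, at which 3 of the 4 values shown sit.

The compounds shown leave open whether a chloro or methoxy group or an amine on this carbon would shift the value likewise. They also leave open whether fluoro here would do so without the fluoro group ortho to it.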